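Swapping the Trihydroxyphenyl Group for a Fluorophenyl

This account rests on a few compounds, and the source may have more. Where it says the series, first, only, none or still open, it means among the compounds named here.

Compound 3 `COc1ccccc1-c1nnc(-c2ccc(C(=O)N/N=C/c3c(O)cc(O)cc3O)cc2)o1` is the most strongly cytotoxic of the three measured compounds: in an ADME assay on THP-1 cells (Homo sapiens) for cytotoxicity (a lower number here means a stronger inhibitor, a higher number a weaker inhibitor), compound 3 gives 12400 nM, the lowest number of the three. Compound 1 `COc1ccccc1-c1nnc(-c2ccc(C(=O)N/N=C/c3ccncc3)cc2)o1` gives 173000 nM and compound 2 `COc1ccc(/C=N/NC(=O)c2ccc(-c3nnc(-c4ccccc4OC)o3)cc2)cc1O` gives 260000 nM. The steps of a 14-fold lower number from compound 1 to compound 3 (1.14 log units; beyond the scatter) and a 21-fold lower number from compound 2 to compound 3 (1.32 log units; beyond the scatter) are both large and beyond the scatter, whereas a 1.5-fold higher number from compound 1 to compound 2 (0.18 log units; within the scatter) stays within it. Compound 4 `COc1ccccc1-c1nnc(-c2ccc(C(=O)N/N=C/c3cccc(F)c3)cc2)o1` differs from compound 3 in one place: 3-fluorophenyl in place of 2,4,6-trihydroxyphenyl on a carbon with a double bond to nitrogen. The two large steps show that the 2,4,6-trihydroxyphenyl group goes with the low number, while the pyridin-4-yl and 3-hydroxy-4-methoxyphenyl groups give numbers within the scatter of each other. Replacing 2,4,6-trihydroxyphenyl by 3-fluorophenyl, a group with no hydrogen-bond donors and no hydrogen-bond acceptors, is therefore expected to undo most of that gain, so that compound 4 is estimated at about 150000 nM, within 50000 nM to 400000 nM, an expected step of a 12-fold higher number from compound 3 to compound 4 (1.08 log units; beyond the scatter).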

Compound 4, half-maximal inhibitory concentration: 353000 nM
Compound 4: the middle estimate sits 2.4-fold (0.37 log units) below what was measured; the measured number falls inside the stated range.
By their numbers in this assay, from the lowest: compound 3; then compounds 1, 2 and 4 (each within the scatter of the next, the first and the last beyond it).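

In this assay the step to 3-fluorophenyl from 2,4,6-trihydroxyphenyl is a 28-fold higher number from compound 3 to compound 4 (1.45 log units; beyond the scatter) and so shows the low number of compound 3 against a third kind of group, one with 0 hydrogen-bond donors. The same group placed against 3-hydroxy-4-methoxyphenyl gives a 1.4-fold higher number from compound 2 to compound 4 (0.13 log units; within the scatter) and placed against pyridin-4-yl gives a 2.0-fold higher number from compound 1 to compound 4 (0.31 log units; beyond the scatter) as a modest step. At this position, on a carbon with a double bond to nitrogen, 2,4,6-trihydroxyphenyl therefore stands apart, while the other three groups lie much closer to one another.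

On these data alone, whether the low number needs all three hydroxyl groups, or whether a phenyl ring carrying an amine or a carboxylic acid would match it, stays open. Nothing available gives a reason for the gap between compound 3 and the others.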